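Indole nitrogen substituent: 1-phenylpropyl replaces 4-(trifluoromethyl)benzyl

The source may hold more compounds than are shown below. What is called first, only, known or untested is meant among the compounds shown, and "the series" means these compounds.

Three members of the series have numbers in an assay on Prostate gland for inhibition of steroid 5-alpha-reductase (Rattus norvegicus); a lower number here means a stronger inhibitor, a higher number a weaker inhibitor. Compound 1 `CCCCCCn1ccc2cc(/C(C)=C/C(=O)Nc3ccccc3OCCCC(=O)O)ccc21` gives 77 nM, compound 2 `C/C(=C\C(=O)Nc1ccccc1OCCCC(=O)O)c1ccc2c(ccn2Cc2ccc(C)cc2)c1` gives 88 nM, and compound 3 `C/C(=C\C(=O)Nc1ccccc1OCCCC(=O)O)c1ccc2c(ccn2Cc2ccc(C(F)(F)F)cc2)c1` gives 300 nM. Compound 3 stands highest of the three, the nearest being compound 2 a 3.4-fold higher number from compound 2 to compound 3 (0.53 log units; beyond the scatter) and the furthest compound 1 a 3.9-fold higher number from compound 1 to compound 3 (0.59 log units; beyond the scatter), while the change a 1.1-fold higher number from compound 1 to compound 2 (0.06 log units; within the scatter) is within the scatter.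

Compound 4 `CCC(c1ccccc1)n1ccc2cc(/C(C)=C/C(=O)Nc3ccccc3OCCCC(=O)O)ccc21` differs from compound 3 in one place: 1-phenylpropyl in place of 4-(trifluoromethyl)benzyl on an aromatic nitrogen. The bearing steps are those that introduced or removed the trifluoromethyl-bearing group: a 3.4-fold higher number from compound 2 to compound 3 (0.53 log units; beyond the scatter) and a 3.9-fold higher number from compound 1 to compound 3 (0.59 log units; beyond the scatter), both modest and both in the direction of a higher number. Compound 4 carries a phenyl ring without trifluoromethyl, like compound 2, with a short branched chain at the nitrogen, like compound 1; those two compounds differ only within the scatter. A modest step back toward lower numbers is therefore expected, a 3.2-fold lower number from compound 3 to compound 4 (0.50 log units; beyond the scatter), and compound 4 is estimated at 95 nM with a range of 45 nM to 200 nM in this assay.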

Compound 4, half-maximal inhibitory concentration: 19 nM
Compound 4: the middle estimate sits 5.0-fold (0.70 log units) above what was measured, and the stated range ends above it.
By their numbers in this assay, from the lowest: compound 4; then compounds 1 and 2 (each within the scatter of the next); then compound 3.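

In this assay, 1-phenylpropyl on the aromatic nitrogen gives a lower number than all three earlier substituents: a 16-fold lower number from compound 3 to compound 4 (1.20 log units; beyond the scatter), a 4.6-fold lower number from compound 2 to compound 4 (0.67 log units; beyond the scatter) and a 4.1-fold lower number from compound 1 to compound 4 (0.61 log units; beyond the scatter), which makes compound 4 the strongest inhibitor of the four. Hexyl and 4-methylbenzyl had given no difference beyond the scatter, so this position looked flat apart from the trifluoromethyl penalty; it now shows clear room for a lower number, reached with a phenyl ring on a branched carbon. Nothing available explains this gain.

On these data alone, how much of the gain belongs to the branching and how much to the unsubstituted phenyl ring stays open. A plain benzyl or a 1-phenylethyl group on the aromatic nitrogen would help divide the two.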